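The source may hold more compounds than are shown below. What is called first, only, known or untested is meant among the compounds shown, and "the series" means these compounds.

Compound 3, `C/N=C(\S)NCCCCn1nc(-c2ccccc2)ccc1=O`, is one of three compounds sharing a core and tested in a functional assay on the whole organism (stomach) with Rattus norvegicus as the target; on this read-out lower numbers stand for an effect already at smaller amounts and higher numbers for an effect only at larger amounts of compound. Compound 1, `CC/N=C(/NC#N)NCCCCn1nc(-c2ccccc2)ccc1=O`, gives 92 mg/kg, compound 2, `N#CNC(=N)NCCCCn1nc(-c2ccccc2)ccc1=O`, gives 77.2 mg/kg, and compound 3 gives 28.9 mg/kg, the lowest of the three. The steps of a 3.2-fold lower number from compound 1 to compound 3 (0.50 log units; beyond the scatter) and a 2.7-fold lower number from compound 2 to compound 3 (0.43 log units; beyond the scatter) set compound 3 apart, while a 1.2-fold lower number from compound 1 to compound 2 (0.08 log units; within the scatter) shows that dropping an ethyl from a nitrogen changed little. Compound 4, `CC(C)C/N=C(\S)NCCCCn1nc(-c2ccccc2)ccc1=O`, carries isopropyl in place of hydrogen on a saturated chain carbon bound to a double-bonded nitrogen. For the measured compounds named here, no measured step alters a carbon on that side of the double-bonded nitrogen, so the expectation leans on the small step from compound 1 to compound 2 and on compound 3 itself. The expected step is a 1.0-fold higher number from compound 3 to compound 4 (0.00 log units; within the scatter), within the scatter. Compound 4 is estimated at 29 mg/kg, ranging from 12 mg/kg to 70 mg/kg.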

Compound 4, dose for half-maximal effect: > 100 mg/kg
Compound 4 gave a limit, no number; the forecaster's own chance of this, stated with the estimate: 10%; middle value at least 3.4-fold (0.53 log units) away from the limit.
By their numbers in this assay, from the lowest: compound 3; then compounds 2 and 1 (each within the scatter of the next). At a limit, above all of these: compound 4.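

In this assay, compound 4 gives only a limit, not a number: the limit of > 100 mg/kg in this assay, at which 1 of the 4 values shown sits. Earlier steps never touched this place, and they did not show that it matters, but isopropyl in place of hydrogen on a saturated chain carbon bound to a double-bonded nitrogen gives an at least 3.4-fold higher number from compound 3 to compound 4 (0.53 log units; beyond the scatter). The steps of an at least 1.2-fold higher number from compound 2 to compound 4 (0.11 log units; that floor lies within the scatter) and an at least 1.0-fold higher number from compound 1 to compound 4 (0.03 log units; that floor lies within the scatter) are floors only. Still open, from the compounds shown here alone, is whether a smaller addition at this saturated chain carbon, such as a single methyl or a hydroxyl, would keep the number of compound 3. Going by these compounds, a straight propyl chain in place of the methyl of compound 3 is equally open.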